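Swapping 3-bromophenyl for naphthalen-2-yl

The source may report more compounds than this note shows. Statements on the series, on what has been measured and on what is new or still open speak of the compounds shown alone.

In a functional assay on HT-1080 cells (Homo sapiens) for antiproliferative activity, read by MTT assay, with a stated time of 72 h (on this read-out lower numbers stand for stronger inhibition and higher numbers for weaker inhibition), compound 1 `COc1ccc(-c2sc(C(=O)O)cc2-c2cc(OC)c(OC)c(OC)c2)cc1` gives 6770 nM. Compound 2 `COc1cc(-c2cc(C(=O)O)sc2-c2cccc(Br)c2)cc(OC)c1OC` gives > 100000 nM, which is a limit of this assay and not a number. Going by the values given here, the one measured step that bears on the next change is an at least 14-fold higher number from compound 1 to compound 2 (1.16 log units; beyond the scatter), a large step made by putting 3-bromophenyl in place of 4-methoxyphenyl. As far as these compounds go, its true size stays open because of the limit of > 100000 nM in this assay, at which 1 of the 2 values shown sits.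

Compound 3 `COc1cc(-c2cc(C(=O)O)sc2-c2ccc3ccccc3c2)cc(OC)c1OC` changes the same aromatic carbon, with naphthalen-2-yl in place of 3-bromophenyl on an aromatic carbon. Compound 1 reaches 6770 nM with another group on that carbon, so a measurable number seems possible here. Compound 3 could also give only a limit. The expected change is an at least 3.3-fold lower number from compound 2 to compound 3 (0.52 log units; beyond the scatter), a moderate step towards a lower number. For compound 3 the estimated value is 30000 nM, with an expected range from 6000 nM to 100000 nM.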

Compound 3, half-maximal inhibitory concentration: 13400 nM
Compound 3: the middle estimate sits 2.2-fold (0.35 log units) above what was measured; the range from low to high includes it.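

In this assay, naphthalen-2-yl on this carbon gives an at least 7.4-fold lower number from compound 2 to compound 3 (0.87 log units; beyond the scatter), so a bulkier aromatic group built of carbon only can bring back a measurable number where 3-bromophenyl gave none. As far as these compounds go, compound 2 stands at a limit of the assay and not a number, so the true size of this step stays open: the limit of > 100000 nM in this assay, at which 1 of the 3 values shown sits. Measured against 4-methoxyphenyl, naphthalen-2-yl gives a 2.0-fold higher number from compound 1 to compound 3 (0.30 log units; within the scatter), so these two groups cannot be told apart here, and an oxygen on this aromatic group is not needed for a measurable number.

From the compounds shown here alone, it stays open whether the bromine itself or its place on the ring goes with the limit seen for compound 2. A plain phenyl or a 4-bromophenyl on this carbon would help to separate these two readings.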